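Phenyl for hydrogen on the aryl ring of compound 2

This account rests on a few compounds, and the source may have more. Where it says the series, first, only, none or still open, it means among the compounds named here.

Measured in a functional assay on NCI-H460 cells (Homo sapiens) for inhibition, read by MTT assay, with a stated time of 48 h; on this read-out lower numbers stand for stronger inhibition of growth and higher numbers for weaker inhibition of growth:
compound 1 `Nc1ccc(-c2cc(-c3ccccc3)n[nH]2)cc1`: 26700 nM
compound 2 `COc1ccc(-c2cc(-c3ccccc3)n[nH]2)cc1`: 10400 nM
compound 3 `COc1ccc(-c2cc(-c3ccc(Cl)cc3)n[nH]2)cc1`: 11600 nM

Compound 2 gives the lowest number of the three, but compound 3 sits within the scatter of it, so no order between those two is claimed; only compound 1 stands clearly apart, as the step of a 2.6-fold lower number from compound 1 to compound 2 (0.41 log units; beyond the scatter) shows.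

Compound 4 `COc1ccc(-c2cc(-c3ccccc3-c3ccccc3)n[nH]2)cc1` differs from compound 2 by phenyl in place of hydrogen on an aromatic carbon, placed on an aromatic carbon of a six-membered aromatic ring of carbon only, ortho to a large group. The step that bears on it is the one on the same ring, a 1.1-fold higher number from compound 2 to compound 3 (0.05 log units; within the scatter), which stayed within the scatter; the other step, a 2.6-fold lower number from compound 1 to compound 2 (0.41 log units; beyond the scatter), concerns the other ring and was modest. Among the measured compounds shown here, no measured step adds a phenyl anywhere, so the size of the new step is not anchored by data. On what is shown, the expectation for compound 4 in this assay is a step of a 1.3-fold higher number from compound 2 to compound 4 (0.13 log units; within the scatter), that is, close to no change beyond the scatter, with the range kept wide. Compound 4 is therefore estimated at 14000 nM, between 5000 nM and 40000 nM.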

Compound 4, concentration for 50% growth inhibition: 730 nM
Estimate against measurement, compound 4: 19-fold (1.28 log units) above; measured number below the stated range.
By their numbers in this assay, from the lowest: compound 4; then compounds 2 and 3 (each within the scatter of the next); then compound 1.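

In this assay, phenyl in place of hydrogen on an aromatic carbon, ortho to a large group, gives a 14-fold lower number from compound 2 to compound 4 (1.15 log units; beyond the scatter) and so is the largest step in the series and the first beyond the scatter on this ring. Among the compounds shown here, the only earlier step on this ring, a 1.1-fold higher number from compound 2 to compound 3 (0.05 log units; within the scatter), stayed within the scatter, so chloro gave no sign of what phenyl now shows; these two steps differ in both the group and its place, and neither factor can be singled out. Nothing measured here accounts for the size of the new step.

Open, as far as these compounds go, is whether phenyl gives a similar step on the carbon that carries chloro in compound 3, and whether methyl or pyridyl in place of the added phenyl of compound 4 keeps the low number. Also open, from the compounds shown here alone, is whether the step holds with amino in place of methoxy, as in compound 1.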